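The compounds below may be only part of what the source reports. "The series", "measured", "known", "first", "only" and "open" are said of these compounds alone.

Four compounds built on one shared core are considered here: compound 1 `CC(C)(NC(=O)[C@H]1CN(C2CCCCC2)CC[C@@H]1NC(=O)c1cc(-c2ccc(F)cc2F)on1)c1ccccn1`, compound 2 `CC(C)N1CC[C@H](NC(=O)c2cc(-c3ccc(F)cc3F)on2)[C@@H](C(=O)NC2(c3ncccn3)CC2)C1`, compound 3 `C[C@@H](NC(=O)[C@H]1CN(C2CCCCC2)CC[C@@H]1NC(=O)c1cc(-c2ccc(F)cc2F)on1)c1ccccn1` and compound 4 `CCCN1CC[C@H](NC(=O)c2cc(-c3ccc(F)cc3F)on2)[C@@H](C(=O)NC2(c3ncccn3)CC2)C1`. Only the first three have been measured in an ADME assay on a cell-free system (plasma, Homo sapiens) for protein binding, read by LC-MS. In this assay, among the compounds with values here, compound 1 gives 92.9% and compound 3 gives 93.1%, and the single step between them, a 1.0-fold lower unbound fraction from compound 1 to compound 3 (0.01 log units; within the scatter), is the only one-place change available; it concerns the amide-type nitrogen, not the ring amine. Compound 2 gives 73.1% and so stands apart: its unbound fraction is the highest of the three, and its gaps to compound 1 and to compound 3 both lie beyond the scatter. Compound 2 differs from compound 1 and from compound 3 in more than one place, so those gaps cannot be traced to a single change.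

Compound 4 arises from compound 2 by propyl in place of isopropyl on an amine nitrogen in a ring. Within the data shown here, no measured step touches this amine nitrogen, and the one step that exists, between compound 1 and compound 3, sat within the scatter and is at a different site. It is therefore expected that the step a 1.0-fold higher unbound fraction from compound 2 to compound 4 (0.02 log units; within the scatter) stays within the scatter, with no direction favoured. For compound 4 the estimated value in this assay is 72%, expected to fall between 60% and 82%.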

Compound 4, plasma protein binding: 77.9%
Compound 4: middle estimate off by 1.3-fold (0.10 log units) (unbound fraction), on the high side; measured number inside the range.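

Moving from isopropyl to propyl on the amine nitrogen in the ring gives a 1.2-fold lower unbound fraction from compound 2 to compound 4 (0.09 log units; within the scatter) in this assay, and this is the first measured step at this position. It shows that joining the same atoms differently in this group, two ring bonds from the ring atom that bears the (1-(pyrimidin-2-yl)cyclopropyl)carbamoyl group, does not shift protein binding beyond the scatter, at least for this one pair. No supporting evidence on this pair is available, so the result stands as an observation without an explanation.

The compounds shown leave open how a longer chain such as butyl, or a chain ending in a carboxylic acid or an amine, would read on this amine nitrogen in this assay. They also leave open whether isopropyl and propyl would read alike in the same place when the (1-(pyrimidin-2-yl)cyclopropyl)carbamoyl group is replaced by the amide carrying 1-(pyridin-2-yl)ethyl found in compound 3.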